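The source may report more compounds than this note shows. Statements on the series, on what has been measured and on what is new or still open speak of the compounds shown alone.

In a functional assay on CHO-K1 cells for agonist activity at Glucose-dependent insulinotropic receptor (Homo sapiens), read by a luciferase reporter, with a stated time of 5 h (on this read-out lower numbers stand for an effect already at smaller amounts and higher numbers for an effect only at larger amounts of compound), compound 2 `CC(C)SC(=O)N1CCC(Oc2ncnc3c2CCN3c2ccc(S(C)(=O)=O)cc2F)CC1` gives 10 nM, the lowest of the two numbers measured; its closest neighbour is compound 1 `CC(C)COC(=O)N1CCC(Oc2ncnc3c2CCN3c2ccc(S(C)(=O)=O)cc2F)CC1`, which in this assay gives 25.1 nM. Among the compounds with values here, the only measured step, a 2.5-fold lower number from compound 1 to compound 2 (0.40 log units; beyond the scatter), swaps one chain for another on the carbonyl carbon that hangs from the ring nitrogen. Compound 3 `CN(C)C(=O)CN1CCC(Oc2ncnc3c2CCN3c2ccc(S(C)(=O)=O)cc2F)CC1` is a different kind of change: (dimethylcarbamoyl)methyl in place of (isopropylsulfanyl)carbonyl on an amine nitrogen in a ring. Here the carbonyl carbon leaves the ring nitrogen altogether and a methylene takes its place, with the carbonyl moved one atom further out. Within the data shown here, no measured step shows what happens when the carbonyl on the ring nitrogen is removed in this way, so the step from compound 1 to compound 2 only tells that this end of the molecule tolerates small changes with modest shifts. A larger shift in this assay is expected for compound 3, towards higher numbers, as a 10-fold higher number from compound 2 to compound 3 (1.00 log units; beyond the scatter). The estimate for compound 3 in this assay is 100 nM, with a range from 20 nM to 600 nM.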

Compound 3, half-maximal effective concentration: > 10000 nM
Compound 3: a limit, no number (the forecaster's own chance of this, stated with the estimate: 10%); at least 100-fold (2.00 log units) between middle value and limit.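

In this assay, compound 3 gives a limit and not a number: the limit of > 10000 nM in this assay, at which 1 of the 3 values shown sits. Replacing the carbonyl-linked chain on the ring nitrogen with (dimethylcarbamoyl)methyl gives an at least 1000-fold higher number from compound 2 to compound 3 (3.00 log units; beyond the scatter), and likewise an at least 390-fold higher number from compound 1 to compound 3 (2.60 log units; beyond the scatter), far more than the earlier swap, which gave a 2.5-fold lower number from compound 1 to compound 2 (0.40 log units; beyond the scatter). This position therefore does not accept every group of this size, since (isopropylsulfanyl)carbonyl and (dimethylcarbamoyl)methyl have the same heavy-atom count, yet the change is large.

The compounds shown do not separate the effect of the methylene now on the ring nitrogen from that of the dimethylamide end, since both changes arrive together in compound 3. On these data alone, whether a dimethylcarbamoyl group set directly on the ring nitrogen, or a plain isobutyl chain there, would restore a measurable number remains open.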